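The compounds below may be only part of what the source reports. "The series", "measured", "known", "first", "only" and "open" are said of these compounds alone.

Among the measured compounds shown here, only two compounds have been tested so far in a functional assay on AGS cells (Homo sapiens) for antiproliferative activity, read by MTT assay, with a stated time of 48 h (on this read-out lower numbers stand for stronger inhibition of growth and higher numbers for weaker inhibition of growth), and only one of them gave a number. Compound 1 `COc1ccccc1OCCNc1ccc(=O)n(Cc2ccc(OC)c(OCC3CC3)c2)n1` gives 45800 nM in this assay. From the compounds shown here alone, compound 2 `COc1ccccc1OCCNc1cnn(Cc2ccc(OC)c(-c3cccc(Cl)c3)c2)c(=O)c1Cl` reads > 100000 nM, which is a limit of this assay and not a number, so its true position is unknown.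

Compound 3 `COc1ccccc1OCCNc1cnn(Cc2ccc(OC)c(OC3CCCC3)c2)c(=O)c1Cl` keeps the rest of compound 2 but has cyclopentyloxy in place of 3-chlorophenyl on an aromatic carbon, ortho to a methoxy group (cyclopentyloxy in place of 3-chlorophenyl on an aromatic carbon). For the measured compounds named here, no measured pair of compounds isolates this change, so any forecast is rough. The closest guide is compound 1, which also carries a non-aromatic carbon ring attached through oxygen and gives 45800 nM, although the rest of its structure differs from compound 3. On that basis, a moderate shift toward stronger inhibition of growth is expected, and the expected step is an at least 1.8-fold lower number from compound 2 to compound 3 (0.25 log units; that floor lies within the scatter). Compound 3 could still end up at the limit of this assay. For compound 3 the estimated value is 55000 nM, with an expected range of 18000 nM to 100000 nM.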

Compound 3, concentration for 50% growth inhibition: > 100000 nM
Compound 3 ended at the assay's limit; the forecaster's own chance of this, stated with the estimate: 35%; middle value at least 1.8-fold (0.25 log units) away from the limit.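

Compound 2 and compound 3 both sit at a limit of this assay, and no step between them can be read because neither gives a number: the limit of > 100000 nM in this assay, at which 2 of the 3 values shown sit.

The compounds shown leave open how far each lies beyond that limit, and whether cyclopentyloxy or 3-chlorophenyl gives stronger inhibition of growth on the shared core.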